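The compounds below may be only part of what the source reports. "The series", "measured", "known", "first", "only" and "open" are said of these compounds alone.

Measured so far in the series:
Compound 1 `CC1(C)CCN(S(=O)(=O)c2ccc(NC(=O)c3ccc([N+](=O)[O-])o3)cc2)CC1`; in an ADME assay on IMR-90 cells (Homo sapiens) for cytotoxicity, read by CellTiter-Blue, with a stated time of 46 h (a higher number here means that more compound is needed for the effect, a lower number that less compound is needed), compound 1 gives only a limit, > 25000 nM.
Compound 2 `CC(C)(C)C1CCN(S(=O)(=O)c2ccc(NC(=O)c3ccc([N+](=O)[O-])o3)cc2)CC1`; in this assay compound 2 gives only a limit, > 25000 nM.
Compound 3 `O=C(Nc1ccc(S(=O)(=O)N2CCC3(CCCCC3)CC2)cc1)c1ccc([N+](=O)[O-])o1`; in this assay compound 3 gives only a limit, > 25000 nM.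

Going by the values given here, compound 2 thus stands where every value shown stands, at the limit of > 25000 nM in this assay, at which 3 of the 3 values shown sit; no compound has yet given a number in this assay. Among the compounds with values here, the only measured change on the sulfonyl-bound ring, a step that the two limits leave unreadable from compound 1 to compound 2, is therefore unreadable, and compound 3 adds a third limit without a direction.

Compound 4 `O=C(Nc1ccc(S(=O)(=O)N2CCC(F)CC2)cc1)c1ccc([N+](=O)[O-])o1` differs from compound 2 by fluoro in place of tert-butyl on a saturated ring carbon, the ring being a six-membered non-aromatic ring with one nitrogen, three ring bonds from the ring nitrogen. Within the data shown here, no measured step reads across this change, and the one step that touches the same ring gives no size. The expectation for compound 4 in this assay therefore rests only on the shared limit: the step that the limit leaves unreadable from compound 2 to compound 4 is expected to be nothing beyond the scatter. Compound 4 is estimated at 40000 nM, within 20000 nM to 100000 nM, most likely again reported as a limit.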

Compound 4, half-maximal effective concentration: > 25000 nM
Compound 4 gave a limit, no number; the forecaster's own chance of this, stated with the estimate: 85%; the middle value lies beyond the limit too.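

In this assay, going by these compounds alone, compound 4 gives > 25000 nM, again a limit, so no step from compound 1 or compound 2 to compound 4 can be read. The compounds shown leave open at what concentration any of them acts, and whether the group on the sulfonyl-bound ring changes that: the limit of > 25000 nM in this assay, at which 4 of the 4 values shown sit.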